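Methoxy for fluoro on the fused ring of compound 1

The compounds below may be only part of what the source reports. "The series", "measured", "known", "first", "only" and "open" are said of these compounds alone.

Measured compounds:
compound 1 `Fc1ccc2c(Cn3ccnc3)c(-c3ccc(Cl)cc3)[nH]c2c1`: 45000 nM
compound 2 `COc1ccc(-c2[nH]c3cc(F)ccc3c2Cn2ccnc2)cc1`: > 1000000 nM

For the measured compounds named here, in an ADME assay on MCF7 cells (Homo sapiens) for cytotoxicity, read by MTT assay, with a stated time of 48 h (on this read-out higher numbers stand for weaker inhibition and lower numbers for stronger inhibition), compound 1 gives 45000 nM, the only number recorded. Compound 2 `COc1ccc(-c2[nH]c3cc(F)ccc3c2Cn2ccnc2)cc1` reaches only the assay limit of > 1000000 nM, which is the limit of > 1000000 nM in this assay, at which 1 of the 2 values shown sits. Going by the values given here, the single measured step is an at least 22-fold higher number from compound 1 to compound 2 (1.34 log units; beyond the scatter). Compound 3 `COc1ccc2c(Cn3ccnc3)c(-c3ccc(Cl)cc3)[nH]c2c1` differs from compound 1 by methoxy in place of fluoro on an aromatic carbon. The step to compound 2 involves a methoxy entering in place of a halogen, but on the other aromatic ring, so it bears on the change to compound 3 only loosely. It nonetheless points toward a weaker inhibition when a methoxy replaces a halogen in this series, and a step toward a higher number in this assay is expected, though of uncertain size and with a real chance of another limit. Compound 3 is therefore estimated at 150000 nM, with a range from 40000 nM to 600000 nM, an expected step of a 3.3-fold higher number from compound 1 to compound 3 (0.52 log units; beyond the scatter).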

Compound 3, half-maximal inhibitory concentration: > 1000000 nM
Compound 3 gave a limit, no number; the forecaster's own chance of this, stated with the estimate: 30%; middle value at least 6.6-fold (0.82 log units) from the limit.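

Compound 2 had shown a methoxy exchange only on the other aromatic ring, whereas compound 3 carries it in place of fluoro on the fused system, and in this assay this gives an at least 22-fold higher number from compound 1 to compound 3 (1.34 log units; beyond the scatter). On these data alone, the value of compound 3, > 1000000 nM, is a limit of the assay and not a number, so the step gives only a minimum and its full size remains unknown. Set against compound 1, methoxy in place of either halogen now leaves no number in this assay, and the two exchanges cannot be ordered against each other: the limit of > 1000000 nM in this assay, at which 2 of the 3 values shown sit.

The compounds shown leave open whether the loss belongs to methoxy in particular or would also follow other replacements for fluoro at this position, such as a hydroxyl, an amine or a methyl. They also leave open whether a plain hydrogen in place of fluoro would keep a measurable value in this assay, which would show how much the fluoro itself contributes to the reading of compound 1.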